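Varying the aryl group on the carbon double-bonded to nitrogen

The source may hold more compounds than are shown below. What is called first, only, known or untested is meant among the compounds shown, and "the series" means these compounds.

Measured so far:
compound 1 `O=C(N/N=C/c1ccc(O)cc1)c1ccc(-c2nc3ccccc3s2)cc1` — 11300 nM
compound 2 `O=C(N/N=C/c1cccc(O)c1O)c1ccc(-c2nc3ccccc3s2)cc1` — 11200 nM
compound 3 `COc1cc(/C=N/NC(=O)c2ccc(-c3nc4ccccc4s3)cc2)cc(OC)c1` — 16200 nM

All three numbers come from an assay on isolated protein for inhibition of Maltase-glucoamylase (Homo sapiens), with a stated time of 15 min; a lower number here means a stronger inhibitor, a higher number a weaker inhibitor. Compound 1 stands second highest of the three, with compound 2 nearest (a 1.0-fold lower number from compound 1 to compound 2 (0.00 log units; within the scatter)) and compound 3 furthest (a 1.4-fold higher number from compound 1 to compound 3 (0.16 log units; within the scatter)); neither step is beyond the scatter, and the same holds for the pair a 1.4-fold higher number from compound 2 to compound 3 (0.16 log units; within the scatter). On these numbers the three compounds cannot be told apart.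

The next compound, compound 4 `O=C(N/N=C/c1ccncc1)c1ccc(-c2nc3ccccc3s2)cc1`, is obtained from compound 1 by the following change:
pyridin-4-yl in place of 4-hydroxyphenyl on a carbon with a double bond to nitrogen

Within the data shown here, no measured step introduces a ring nitrogen at this place, so none bears on it directly. What the measured steps do show is that swapping the ring substituents on this aryl group — from compound 1 to compound 2 and from compound 1 to compound 3 — left this assay within the scatter. Among the measured compounds shown here, on that basis the step to compound 4 is expected to stay small as well, with a shift of a 1.2-fold higher number from compound 1 to compound 4 (0.08 log units; within the scatter) from compound 1 to compound 4 expected, toward a slightly higher number, since the removal of the hydroxyl donor is the only change without precedent here.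

Compound 4 is therefore estimated at 13500 nM in this assay, with a range of 6000 nM to 32000 nM.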

Compound 4, half-maximal inhibitory concentration: "not active" (no number reported)
No number was reported for compound 4, so the estimate cannot be set against anything.
By their numbers in this assay, from the lowest: compounds 2, 1 and 3 (each within the scatter of the next).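

Among these compounds, compound 4 is recorded as "not active" in this assay, with no number, so no step linking it to compound 1, compound 2 or compound 3 can be read. Nothing available bears on this result. The compounds shown leave open how pyridin-4-yl in place of 4-hydroxyphenyl compares numerically in this assay.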